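Replacing fluoro with hydroxy in a growth-inhibitor series

A few compounds are considered here, and "the series" means these few. Any claim that something is new, unique, unknown or untested is made for them only; others in the source may bear on it.

Measured compounds:
Compound 1, `O=S(=O)(/C=C/c1ccc(F)cc1)Cc1ccc(Nc2ncnc3ccccc23)cc1`: 1000 nM
Compound 2, `O=S(=O)(/C=C/c1ccc(Cl)cc1)Cc1ccc(Nc2ncnc3ccccc23)cc1`: 73000 nM
Compound 3, `O=S(=O)(/C=C/c1ccc(F)cc1Cl)Cc1ccc(Nc2ncnc3ccccc23)cc1`: 100000 nM

These numbers come from a functional assay on HT-29 cells (Homo sapiens); a higher number here means a weaker inhibitor of growth, a lower number a stronger inhibitor of growth. Compound 1 stands lowest of the three; its nearest measured neighbour lies a 73-fold higher number from compound 1 to compound 2 (1.86 log units; beyond the scatter), and the furthest a 100-fold higher number from compound 1 to compound 3 (2.00 log units; beyond the scatter). Both steps are far beyond the scatter.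

Compound 4, `O=S(=O)(/C=C/c1ccc(O)cc1)Cc1ccc(Nc2ncnc3ccccc23)cc1`, is not yet measured. It differs from compound 1 by hydroxy in place of fluoro on an aromatic carbon. Going by the values given here, no measured step exchanges fluoro for hydroxy, so no step bears on this change directly. The two steps that start from compound 1, a 73-fold higher number from compound 1 to compound 2 (1.86 log units; beyond the scatter) and a 100-fold higher number from compound 1 to compound 3 (2.00 log units; beyond the scatter), alter the same ring and both are large increases, showing that this ring does not tolerate every change; a hydroxy group, bringing a donor and an acceptor, is a different kind of change from chloro, so their size cannot simply be carried over. The expected outcome is an increase of uncertain size, a 5.0-fold higher number from compound 1 to compound 4 (0.70 log units; beyond the scatter). Compound 4 is estimated at 5000 nM, within a range of 1000 nM to 50000 nM.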

Compound 4, concentration for 50% growth inhibition: 2000 nM
Compound 4: the middle estimate sits 2.5-fold (0.40 log units) above what was measured; the measured number falls inside the stated range.
By their numbers in this assay, from the lowest: compounds 1 and 4 (each within the scatter of the next); then compounds 2 and 3 (each within the scatter of the next).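

In this assay hydroxy in place of fluoro on this aromatic carbon gives a 2.0-fold higher number from compound 1 to compound 4 (0.30 log units; within the scatter) and so shows that the position can carry a group with a hydrogen-bond donor and acceptor without a change that stands clear of the scatter. The earlier compounds shown here showed only large rises on this ring, but these are now seen not to apply to every replacement of fluoro: hydroxy in place of chloro gives a 37-fold lower number from compound 2 to compound 4 (1.56 log units; beyond the scatter) and thus separates two groups of one heavy atom each. Likewise, 4-hydroxyphenyl in place of 2-chloro-4-fluorophenyl gives a 50-fold lower number from compound 3 to compound 4 (1.70 log units; beyond the scatter) as another large step. Whether an amine or a methoxy group here would stay close to fluoro and hydroxy or fall with chloro remains open, and no measurement shown explains the gap between chloro and hydroxy.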